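The source may report more compounds than this note shows. Statements on the series, on what has been measured and on what is new or still open speak of the compounds shown alone.

Measured in a functional assay on HT-29 cells (Homo sapiens) for inhibition, read by MTT assay, with a stated time of 72 h; a higher number here means a weaker inhibitor, a lower number a stronger inhibitor:
Compound 1 `COc1cc(NC(=O)/C=C/c2cccc(OCc3ccccc3)c2)cc(OC)c1OC`: 3600 nM
Compound 2 `C=C(Br)C(=O)Nc1cccc(/C=C/C(=O)Nc2ccc(OC)c(OC)c2)c1`: 1900 nM

In this assay, compound 2 gives 1900 nM and compound 1 gives 3600 nM, two values within the usual scatter of each other. Compound 3 `C=C(Br)C(=O)Nc1cccc(/C=C/C(=O)Nc2cc(OC)c(OC)c(OC)c2)c1` differs from compound 2 by methoxy in place of hydrogen on an aromatic carbon. Going by the values given here, no measured pair shows what such a change does here, so only a modest move towards a stronger inhibitor is expected, estimated as a 1.7-fold lower number from compound 2 to compound 3 (0.24 log units; within the scatter). For compound 3, the estimated value is 1100 nM, with an expected range from 300 nM to 3500 nM.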

Compound 3, half-maximal inhibitory concentration: 2300 nM
Compound 3: the middle estimate sits 2.1-fold (0.32 log units) below what was measured; low and high end bracket the measured number.
By their numbers in this assay, from the lowest: compounds 2, 3 and 1 (each within the scatter of the next).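

In this assay, going by these compounds alone, the step of a 1.2-fold higher number from compound 2 to compound 3 (0.08 log units; within the scatter) gives the first reading of this aromatic carbon, ortho to a methoxy group: methoxy in place of hydrogen stays within the scatter. The wider change of ((1-bromoethenyl)carbonyl)amino in place of benzyloxy, a 1.6-fold lower number from compound 1 to compound 3 (0.19 log units; within the scatter), also stays within the scatter. On these data alone, whether a hydroxyl group or an amine on this aromatic carbon would move the number beyond the scatter remains open. Nothing available explains either step.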